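A few compounds are considered here, and "the series" means these few. Any claim that something is new, unique, unknown or untested is made for them only; others in the source may bear on it.

In a functional assay on Caco-2 cells (Homo sapiens) for inhibition, read by sulforhodamine B assay, with a stated time of 48 h (on this read-out higher numbers stand for weaker inhibition and lower numbers for stronger inhibition), compound 1 `CCO[C@H]1C[C@@H](c2coc3ccccc3c2=O)N(c2ccccc2)O1` gives > 60000 nM, which is a limit of the assay and not a number. Within the data shown here, compound 2 `CCO[C@H]1C[C@@H](c2coc3ccc(C)cc3c2=O)N(c2ccccc2)O1` gives 31000 nM, the only true number so far. Compound 3 `Cc1ccc2occ([C@@H]3C[C@H](OCC(C)C)ON3c3ccccc3)c(=O)c2c1` differs from it by isopropyl in place of methyl on a saturated chain carbon bound to an oxygen on a saturated carbon, which turns ethoxy into isobutoxy. Among the measured compounds shown here, the one measured step, an at least 1.9-fold lower number from compound 1 to compound 2 (0.28 log units; that floor lies within the scatter), sits on an aromatic carbon, so it offers no direct guide to a change on this chain. The estimated change is a 1.2-fold lower number from compound 2 to compound 3 (0.09 log units; within the scatter), with nothing expected beyond the scatter. Compound 3 is expected at 25000 nM, within an estimated range of 10000 nM to 60000 nM.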

Compound 3, half-maximal inhibitory concentration: > 60000 nM
Compound 3: a limit, no number; the forecaster's own chance of this, stated with the estimate: 25%; at least 2.4-fold (0.38 log units) between middle value and limit.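

In this assay, turning ethoxy into isobutoxy on the saturated chain carbon gives an at least 1.9-fold higher number from compound 2 to compound 3 (0.28 log units; that floor lies within the scatter), so this position shows a first direction, though the printed floor does not clear the scatter. From the compounds shown here alone, the value of compound 3 is a limit and not a number, so the true size of the step stays unknown. That limit is also where most of this small set ends up: the limit of > 60000 nM in this assay, at which 2 of the 3 values shown sit. The compounds shown leave open how a shorter chain such as methoxy, or an amine on this chain, would read on the core of compound 2.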